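Chain substituent change on compound 2: chloro to benzyloxy

The source may hold more compounds than are shown below. What is called first, only, known or untested is meant among the compounds shown, and "the series" means these compounds.

Three compounds of the series carry numbers in a functional assay on HEK293 cells for antagonist activity at Voltage-dependent L-type calcium channel subunit alpha-1D (Rattus norvegicus), read by FLIPR; on this read-out higher numbers stand for weaker inhibition and lower numbers for stronger inhibition. Compound 1 `C=CCOC(=O)C1=C(C)NC(C)=C(C(=O)OC)C1c1ccccc1[N+](=O)[O-]` gives 10 nM, compound 2 `COC(=O)C1=C(C)NC(C)=C(C(=O)OCCCl)C1c1cccc([N+](=O)[O-])c1` gives 22 nM, and compound 3 `CCOC(=O)C1=C(C)NC(C)=C(C(=O)OCc2ccc([N+](=O)[O-])cc2)C1c1cccc([N+](=O)[O-])c1` gives 140 nM. Compound 2 thus stands second highest of the three: its nearest neighbour is compound 1 with a lower number, a gap beyond the scatter, and compound 3 lies furthest from it with a higher number, also beyond the scatter.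

Compound 4 `COC(=O)C1=C(C)NC(C)=C(C(=O)OCCOCc2ccccc2)C1c1cccc([N+](=O)[O-])c1` has not yet been measured in this assay. Relative to compound 2 the change is benzyloxy in place of chloro on a saturated chain carbon, two bonds along the chain from an oxygen next to a carbonyl group. For the measured compounds named here, no measured pair shows this particular change, so nothing in the existing numbers fixes the size or sign of the step. The three values span a range beyond the scatter, which shows that changes on this part of the molecule can move the number, and compound 3, the highest of the three, sets the upper edge of what has been seen so far. The step from compound 2 to compound 4 is expected to be small and towards a higher number, a 2.0-fold higher number from compound 2 to compound 4 (0.31 log units; beyond the scatter), not clearly beyond the scatter. Compound 4 is estimated at 45 nM, with a range from 15 nM to 150 nM.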

Compound 4, half-maximal inhibitory concentration: 12 nM
Beside the measured number, compound 4's estimate is 3.8-fold (0.57 log units) above it; the whole stated range lies above it.
By their numbers in this assay, from the lowest: compounds 1, 4 and 2 (each within the scatter of the next, the first and the last beyond it); then compound 3.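

In this assay, for the compounds shown here, benzyloxy in place of chloro on a saturated chain carbon, two bonds along the chain from an oxygen next to a carbonyl group, gives a 1.8-fold lower number from compound 2 to compound 4 (0.26 log units; within the scatter), the first step that can be read at a single place. The earlier compounds shown here differed in several places at once, whereas this pair shows that a group with a six-membered aromatic ring of carbon only and one hydrogen-bond acceptor can replace a lone chlorine at this position without the number leaving the scatter, so the position takes a far larger group with no measurable penalty or gain. The data on hand offer no explanation for this outcome.

As far as these compounds go, what remains open is whether this holds for other kinds of group at the end of the chain, such as a tertiary amine, a carboxylic acid or a hydroxyl, and whether a longer chain between the ester oxygen and the benzyloxy would keep the number in the same place. From the compounds shown here alone, it is also open whether substituents on the phenyl ring of the benzyloxy, such as methoxy or fluoro, would shift the number beyond the scatter.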